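A few compounds are considered here, and "the series" means these few. Any claim that something is new, unique, unknown or untested is made for them only; others in the source may bear on it.

Measured so far in an ADME assay on microsomes from liver (Homo sapiens) for metabolic stability, using NADPH, with a stated time of 40 min, tested at 2 uM; on this read-out higher numbers stand for a longer-lived compound and lower numbers for a shorter-lived compound:
Compound 1 `Cc1cccc2c(-c3ccc4ccc(F)cc4n3)c[nH]c12`: 0.883 h
Compound 2 `Cc1cccc2c(-c3ccc4c(O)cccc4n3)c[nH]c12`: 0.283 h

Compound 2 has the lower of these two half-lives, and its gap to compound 1 lies beyond the usual scatter of repeated measurements. Compound 3 `Cc1cccc2c(-c3ccc4c(F)cccc4n3)c[nH]c12` differs from compound 2 in a single group: fluoro in place of hydroxy on an aromatic carbon. In words, this is fluoro in place of hydroxy on an aromatic carbon. Among the measured compounds shown here, no measured pair shows this exact change on its own, so any forecast is rough. For the measured compounds named here, a longer half-life is expected because compound 1, the only measured compound with a fluoro group, gives 0.883 h. The expected change is a 2.8-fold higher number from compound 2 to compound 3 (0.45 log units; beyond the scatter), a rise probably beyond the scatter. For compound 3 the estimated half-life is 0.8 h, with an expected range from 0.4 h to 1.6 h.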

Compound 3, half-life: 0.217 h
For compound 3 the middle estimate is 3.7-fold (0.57 log units) above the measured one; the whole stated range lies above it.
By their numbers in this assay, from the lowest: compounds 3 and 2 (each within the scatter of the next); then compound 1.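

In this assay putting fluoro in place of hydroxy on this aromatic carbon gives a 1.3-fold lower number from compound 2 to compound 3 (0.12 log units; within the scatter) and so no clear change in half-life at this position, even though the hydrogen-bond donor and acceptor counted for hydroxy leave with it. A fluoro group on the shared core does not by itself go with the higher number: compound 3 gives 0.217 h and compound 1, with its fluoro at a different place, gives 0.883 h on the same read-out. Nothing measured here explains why this swap leaves the half-life within the scatter.

Still open, as far as these compounds go, is whether a methoxy group or an amine on this same carbon would also stay within the scatter of compound 2. From the compounds shown here alone, it is equally open whether a second ring substituent, such as a chlorine, would change the picture.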